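The source may hold more compounds than are shown below. What is called first, only, known or untested is meant among the compounds shown, and "the series" means these compounds.

Three compounds sharing one core and differing in the group on a carbonyl carbon have been measured in an in vivo functional assay on the whole organism for inhibition, with Rattus norvegicus as the target; on this read-out lower numbers stand for an effect already at smaller amounts and higher numbers for an effect only at larger amounts of compound. Compound 1 `CCCCc1nc(C)c(CC(=O)N(C)C)c(=O)n1Cc1ccc(-c2ccccc2-c2nnn[nH]2)cc1` gives 0.018 mg/kg, compound 2 `CCCCc1nc(C)c(CC(=O)N2CCC[C@H]2C(N)=O)c(=O)n1Cc1ccc(-c2ccccc2-c2nnn[nH]2)cc1` gives 0.023 mg/kg, and compound 3 `CCCCc1nc(C)c(CC(=O)N2CCSCC2)c(=O)n1Cc1ccc(-c2ccccc2-c2nnn[nH]2)cc1` gives 0.038 mg/kg. To place compound 3, the step of a 2.1-fold higher number from compound 1 to compound 3 (0.32 log units; beyond the scatter) lies modestly beyond the scatter, while the step of a 1.7-fold higher number from compound 2 to compound 3 (0.22 log units; within the scatter) lies within it.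

Compound 4 `CCCCc1nc(C)c(CCC(=O)N2CCSCC2)c(=O)n1Cc1ccc(-c2ccccc2-c2nnn[nH]2)cc1` keeps the thiomorpholin-4-yl group but lengthens the chain that carries it: ((thiomorpholin-4-yl)carbonyl)methyl in place of (thiomorpholin-4-yl)carbonyl on a saturated chain carbon bound to an aromatic carbon. Put simply, ((thiomorpholin-4-yl)carbonyl)methyl stands in place of (thiomorpholin-4-yl)carbonyl on a saturated chain carbon bound to an aromatic carbon.

Going by the values given here, no measured step makes this kind of change, so the evidence is only indirect. The closest guide is the exchange of groups on the carbonyl carbon, where the step of a 1.3-fold higher number from compound 1 to compound 2 (0.11 log units; within the scatter) stayed within the scatter and the step of a 2.1-fold higher number from compound 1 to compound 3 (0.32 log units; beyond the scatter) only just passed it. Those three compounds therefore suggest a small effect, although lengthening a chain is a different change and could matter more. The expected step is a 1.6-fold higher number from compound 3 to compound 4 (0.20 log units; within the scatter), a slightly higher number but still within the scatter. The estimate for compound 4 is 0.06 mg/kg, with an expected range from 0.018 mg/kg to 0.2 mg/kg.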

Compound 4, dose for half-maximal effect: 0.204 mg/kg
Compound 4: middle estimate off by 3.4-fold (0.53 log units), on the low side; measured number outside the range, above it.
By their numbers in this assay, from the lowest: compounds 1, 2 and 3 (each within the scatter of the next, the first and the last beyond it); then compound 4.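

In this assay, the length of the chain carrying the amide proves to be a sensitive feature of these compounds: with ((thiomorpholin-4-yl)carbonyl)methyl in place of (thiomorpholin-4-yl)carbonyl on the saturated chain carbon bound to an aromatic carbon, the thiomorpholin-4-yl group stays the same and the result is a 5.4-fold higher number from compound 3 to compound 4 (0.73 log units; beyond the scatter). Going by these compounds alone, compound 4 also stands clearly apart from the two other compounds, with an 8.9-fold higher number from compound 2 to compound 4 (0.95 log units; beyond the scatter) and an 11-fold higher number from compound 1 to compound 4 (1.05 log units; beyond the scatter), the last being the only step so far rated large, although both of these steps change the group on the amide nitrogen as well as the chain. Nothing measured here explains why the longer chain goes with a higher dose.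

From the compounds shown here alone, it remains open whether the longer chain would give a similar step with another amide, such as a 2-(dimethylcarbamoyl)ethyl group, or whether this step is tied to the thiomorpholin-4-yl group. The compounds shown also leave open what a still longer chain would do, or a carboxylic acid in place of the amide at the end of the chain.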